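The source may hold more compounds than are shown below. What is called first, only, known or untested is meant among the compounds shown, and "the series" means these compounds.

Compounds measured in a functional assay on the whole organism for inhibition, with Rattus norvegicus as the target (a higher number here means that more compound is needed for the effect, a lower number that less compound is needed), so far:
compound 1 `CC1CC/C(=N\Nc2ccccc2F)c2ncc(C(=O)O)c(=O)n21`: 5 umol/kg
compound 2 `CC1CC/C(=N\Nc2cccc(Cl)c2)c2ncc(C(=O)O)c(=O)n21`: 0.6 umol/kg
compound 3 `CC1CC/C(=N\Nc2cccc(Br)c2)c2ncc(C(=O)O)c(=O)n21`: 0.4 umol/kg

Compound 3 has the lowest of the three numbers, but its gap to compound 2 is within the scatter a 1.5-fold lower number from compound 2 to compound 3 (0.18 log units; within the scatter), so the two cannot be ordered; only compound 1 stands clearly apart, with a 13-fold lower number from compound 1 to compound 3 (1.10 log units; beyond the scatter).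

The next compound, compound 4 `CCOc1cccc(N/N=C2\CCC(C)n3c2ncc(C(=O)O)c3=O)c1`, differs from compound 3 by ethoxy in place of bromo on an aromatic carbon.

Which measured steps bear on this? an 8.3-fold lower number from compound 1 to compound 2 (0.92 log units; beyond the scatter) and a 13-fold lower number from compound 1 to compound 3 (1.10 log units; beyond the scatter) each change both the group and its place on the ring at once, so they say little about an exchange on the same aromatic carbon. a 1.5-fold lower number from compound 2 to compound 3 (0.18 log units; within the scatter) is the closest precedent: bromo for chloro on that aromatic carbon gave no change beyond the scatter. Within the data shown here, no measured step exchanges a halogen for an ethoxy group, and no measured compound carries an oxygen on the phenyl ring, so the data give no direct guide.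

Since the place is retained, compound 4 is expected to stay near compound 2 and compound 3, with a somewhat higher number allowed for the unprecedented group; the estimated step is a 2.5-fold higher number from compound 3 to compound 4 (0.40 log units; beyond the scatter). Compound 4 is estimated at 1 umol/kg, within 0.3 umol/kg to 4 umol/kg.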

Compound 4, dose for 50% inhibition: 0.2 umol/kg
Beside the measured number, compound 4's estimate is 5.0-fold (0.70 log units) above it; measured number below the stated range.
By their numbers in this assay, from the lowest: compounds 4, 3 and 2 (each within the scatter of the next, the first and the last beyond it); then compound 1.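

In this assay, among these compounds, ethoxy is the first group on this aromatic carbon that is not a halogen, bringing 3 heavy atoms and 1 hydrogen-bond acceptor where bromo has 1 heavy atom and no acceptor, yet a 2.0-fold lower number from compound 3 to compound 4 (0.30 log units; within the scatter) leaves compound 4 and compound 3 unordered. Against chloro the same kind of exchange does separate, with a 3.0-fold lower number from compound 2 to compound 4 (0.48 log units; beyond the scatter), even though compound 2 and compound 3 cannot be ordered themselves, so this place accepts an oxygen-linked chain with no loss of effect in the compounds shown. Nothing on hand gives a measured basis for this result.

As far as these compounds go, whether this tolerance reaches beyond ethoxy stays open: methoxy, a longer alkoxy chain, an amine or a carboxylic acid on this aromatic carbon would each test it. Also open is whether ethoxy behaves the same way on another carbon of that ring, as no compound shown separates the effect of place from the effect of group.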